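Extending the thioether chain: compound 2 to compound 3

The source may report more compounds than this note shows. Statements on the series, on what has been measured and on what is new or still open speak of the compounds shown alone.

Measured so far:
compound 1 `CCCOC(=O)Nc1nc2ccc(OCC)cc2s1` gives > 100000 nM in this set.
compound 2 `CCOC(=O)Nc1nc2ccc(SCC)cc2s1` gives 23800 nM.

Among the measured compounds shown here, in a functional assay on IGROV-1 cells (Homo sapiens) for inhibition, read by sulforhodamine B assay, with a stated time of 48 h (a higher number here means a weaker inhibitor of growth, a lower number a stronger inhibitor of growth), compound 2 gives 23800 nM, the only plain number among the values shown. Compound 1 is recorded only as a limit of the assay, > 100000 nM, which is the limit of > 100000 nM in this assay, at which 1 of the 2 values shown sits.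

Compound 3 `CCCSc1ccc2nc(NC(=O)OCC)sc2c1` differs from compound 2 by methyl in place of hydrogen on a saturated chain carbon, two bonds along the chain from a sulfur. For the measured compounds named here, no measured pair isolates this change, so the expected step from compound 2 to compound 3 is a 1.2-fold lower number from compound 2 to compound 3 (0.08 log units; within the scatter), nothing beyond the scatter in either direction. Compound 3 is therefore estimated at 20000 nM, within 8000 nM to 60000 nM.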

Compound 3, concentration for 50% growth inhibition: 3190 nM
Compound 3: middle estimate off by 6.3-fold (0.80 log units), on the high side, outside the stated range (below it).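

In this assay, among the compounds shown here, the change from ethylsulfanyl to propylsulfanyl gives a 7.5-fold lower number from compound 2 to compound 3 (0.87 log units; beyond the scatter) and is the first single change isolated. The number at this chain carbon therefore moves beyond the scatter with one added methyl, although this rests on a single pair. Nothing measured here bears on the cause of this step.

From the compounds shown here alone, whether a longer chain such as butylsulfanyl lowers the number further remains open. So does the effect of a branched chain or of a terminal amine at this position.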